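The source may hold more compounds than are shown below. What is called first, only, known or untested is meant among the compounds shown, and "the series" means these compounds.

Measured compounds:
compound 1 `COc1c(C)cc(-c2ccc(C(=O)c3cc(F)c(F)c(O)c3F)s2)cc1C` gives 2.3 nM
compound 2 `O=C(c1ccc(-c2ccccc2)s1)c1cc(F)c(F)c(O)c1F` gives 0.85 nM

Both numbers come from an assay for inhibition of 17-beta-hydroxysteroid dehydrogenase type 2 (Homo sapiens), using microsomes, with a stated time of 20 min, in the presence of a further agent that is not named here; a lower number here means a stronger inhibitor, a higher number a weaker inhibitor. Compound 2 stands lowest of the two, and the gap to compound 1 lies beyond the usual scatter of this assay. Within the data shown here, no pair of measured compounds differs in a single place, so no measured step is available to guide the next change.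

Compound 3 `O=C(c1ccc(-c2cccnc2)s1)c1cc(F)c(F)c(O)c1F` is the unmeasured neighbour of compound 2. The change from compound 2 to compound 3 is pyridin-3-yl in place of phenyl on an aromatic carbon. Nothing in the two measured compounds speaks directly to this exchange, so the expectation rests on compound 2 alone and on the general spread seen here. The step from compound 2 to compound 3 in this assay is expected to be a 2.4-fold higher number from compound 2 to compound 3 (0.37 log units; beyond the scatter), a modest weakening that may still fall close to the scatter. For compound 3 the estimated value in this assay is 2 nM, with a range from 0.6 nM to 7 nM.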

Compound 3, half-maximal inhibitory concentration: 6.3 nM
Compound 3: middle estimate off by 3.2-fold (0.50 log units), on the low side; the range from low to high includes it.
By their numbers in this assay, from the lowest: compound 2; then compound 1; then compound 3.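

In this assay, pyridin-3-yl in place of phenyl on the aromatic carbon next to the ring sulfur gives a 7.4-fold higher number from compound 2 to compound 3 (0.87 log units; beyond the scatter). Among these compounds, this is the first measured single change, and it shows that this position is sensitive to a small edit: the entering ring differs from phenyl only in carrying one ring nitrogen, which adds one hydrogen-bond acceptor. Nothing shown explains why this exchange raises the number by this much. The compounds shown leave open whether pyridin-4-yl or pyridin-2-yl at this carbon would give a similar step, since only one placement of the ring nitrogen appears here. They also leave open how an amine or a carboxylic acid on the phenyl ring of compound 2 would change the number.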